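The source may hold more compounds than are shown below. What is called first, only, known or untested is meant among the compounds shown, and "the series" means these compounds.

Of the compounds shown here, two in this set have been measured in an in vitro functional assay on cells for antagonist activity at transient receptor potential cation channel subfamily V member 1 (Homo sapiens), read by FLIPR and calcium flux; on this read-out higher numbers stand for weaker inhibition and lower numbers for stronger inhibition. Compound 1 `Cc1ccc(-c2cnc(Nc3cccc4c3CC(O)CC4)o2)cc1` gives 62 nM, and compound 2 `COC1CCc2cccc(Nc3ncc(-c4ccc(C(F)(F)F)cc4)o3)c2C1` gives 150 nM. Compound 2 therefore stands at the higher of the two numbers, and its gap to compound 1 lies beyond the scatter. Compound 2 differs from compound 1 in more than one place, however, so these two values alone do not show which change carries that gap.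

Compound 3 `NC1CCc2cccc(Nc3ncc(-c4ccc(C(F)(F)F)cc4)o3)c2C1` has not yet been measured in this assay. It differs from compound 2 by amino in place of methoxy on a saturated ring carbon. Among the compounds with values here, no measured pair shows this exact change, so the size of the step rests on limited evidence. Compound 1 carries a hydroxy group, which brings a hydrogen-bond donor like the amino group does, and gives 62 nM, which suggests such a group is tolerated on the saturated ring. Compound 3 is therefore expected to give 110 nM, within a range of 40 nM to 350 nM. This means an expected step of a 1.4-fold lower number from compound 2 to compound 3 (0.13 log units; within the scatter), a small move toward stronger inhibition that may well stay within the scatter.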

Compound 3, half-maximal inhibitory concentration: 327 nM
Beside the measured number, compound 3's estimate is 3.0-fold (0.47 log units) below it, within the range that was stated.
By their numbers in this assay, from the lowest: compound 1; then compound 2; then compound 3.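

Replacing methoxy with amino on a saturated ring carbon gives a 2.2-fold higher number from compound 2 to compound 3 (0.34 log units; beyond the scatter) in this assay, a modest move toward weaker inhibition. Within the data shown here, because compound 2 and compound 3 differ in this one place only, this is the first direct reading of the position, and it shows that inhibition responds to the group placed there, with the amino group, which carries a hydrogen-bond donor that methoxy lacks, on the weaker side of the pair. Among these compounds, the one step gives its size and direction for this single exchange, but nothing measured here accounts for it.

Compound 1 carries a hydroxy group but differs from compound 2 and compound 3 in more than one place, so the effect of hydroxy at this position cannot be read separately from its other differences. As far as these compounds go, it remains open how hydroxy would read on the exact core shared by compound 2 and compound 3, and whether a dimethylamino group, an acetamide or a carboxylic acid on the same ring carbon would move the number further in either direction.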